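A few compounds are considered here, and "the series" means these few. Any claim that something is new, unique, unknown or untested is made for them only; others in the source may bear on it.

Measured in a functional assay on NCI-H460 cells (Homo sapiens) for positive allosteric modulation, read by MTT assay, with stated times of 2 h and 72 h, tested at 3 uM; on this read-out higher numbers stand for weaker inhibition and lower numbers for stronger inhibition:
Compound 1 `COc1cccc(-n2nnc(-c3ccccc3NC(=O)c3ccc(N=[N+]=[N-])cc3)n2)c1` gives 455 nM
Compound 2 `COc1ccc(NC(=O)Nc2ccccc2-c2nnn(-c3ccc(OC)cc3)n2)cc1` gives 229 nM

Compound 1 (455 nM) and compound 2 lie within the usual scatter of each other, so neither stands apart. Compound 3 `COc1cccc(-n2nnc(-c3ccccc3NC(=O)Nc3ccc(N)cc3)n2)c1` carries (4-aminophenyl)amino in place of 4-azidophenyl on a carbonyl carbon. Among the compounds with values here, no measured step shows what such a swap does in this assay, so no change beyond the scatter is expected. The expected step (a 1.5-fold lower number from compound 1 to compound 3 (0.18 log units; within the scatter)) is small and towards a lower number. For compound 3 the estimated value is 300 nM with an expected range from 90 nM to 1000 nM.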

Compound 3, half-maximal inhibitory concentration: 216 nM
Compound 3: middle estimate off by 1.4-fold (0.14 log units), on the high side; the measured number falls inside the stated range.
By their numbers in this assay, from the lowest: compounds 3, 2 and 1 (each within the scatter of the next, the first and the last beyond it).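

In this assay, within the data shown here, placing (4-aminophenyl)amino in place of 4-azidophenyl on a carbonyl carbon gives a 2.1-fold lower number from compound 1 to compound 3 (0.32 log units; beyond the scatter) and is the first one-place comparison here. It shows that this position accepts the change with a modest gain in inhibition, a step just beyond the scatter. Nothing measured here explains the step. The compounds shown leave open whether the gain follows the amine or the nitrogen attached to the carbonyl carbon, since both change together. A (4-azidophenyl)amino group on that carbon would separate the two.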